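The source may report more compounds than this note shows. Statements on the series, on what has been measured and on what is new or still open speak of the compounds shown alone.

Measured in a functional assay on A549 cells (Homo sapiens) for antiproliferative activity, read by MTT assay, with a stated time of 72 h; a higher number here means a weaker inhibitor, a lower number a stronger inhibitor:
- Compound 1 `N=C(NC(=N)NC1CCCC1)Nc1ccc(C(F)(F)F)cc1`: 1800 nM
- Compound 2 `CC(C)NC(=N)NC(=N)Nc1ccc(F)c(F)c1`: 5200 nM
- Compound 3 `CCCCCCCNC(=N)NC(=N)Nc1ccc(F)c(F)c1`: 1500 nM

Compound 1 lies within the usual scatter of compound 3, and compound 2 stands clearly higher than both, which means weaker. Compound 4 `CCN(CC)C(=N)NC(=N)Nc1ccc(C(F)(F)F)cc1` has not been measured. It differs from compound 1 as follows: diethylamino in place of cyclopentylamino on a carbon with a double bond to nitrogen. Among the measured compounds shown here, only one measured step bears on this change, a 3.5-fold lower number from compound 2 to compound 3 (0.54 log units; beyond the scatter). That step swapped one chain on an amine nitrogen for another, so such groups can matter, but only modestly here. For the measured compounds named here, no measured compound carries diethylamino, and the direction stays uncertain. The expected step is small, a 1.4-fold higher number from compound 1 to compound 4 (0.14 log units; within the scatter), leaning only slightly towards a weaker number. For compound 4 the estimate is 2500 nM, with an expected range of 1000 nM to 6500 nM.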

Compound 4, half-maximal inhibitory concentration: 3700 nM
Beside the measured number, compound 4's estimate is 1.5-fold (0.17 log units) below it, and the stated range covers the measured number.
By their numbers in this assay, from the lowest: compounds 3 and 1 (each within the scatter of the next); then compounds 4 and 2 (each within the scatter of the next).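

On a carbon with a double bond to nitrogen, the amine group matters: in this assay, diethylamino in place of cyclopentylamino gives a 2.1-fold higher number from compound 1 to compound 4 (0.31 log units; beyond the scatter), a modest step beyond the scatter. This single change removes both the ring and the hydrogen-bond donor of cyclopentylamino, so the step cannot separate the two. No available evidence accounts for the shift.

Which of the two differences counts remains open. Pentylamino, an open chain that keeps the nitrogen's hydrogen, and pyrrolidinyl, a ring without it, could pull them apart.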